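One methyl group less on compound 1

The source may report more compounds than this note shows. Statements on the series, on what has been measured and on what is new or still open speak of the compounds shown alone.

Values in a physicochemical assay for solubility, measured as kinetic solubility, at pH 7.4 (a lower number here means a less soluble compound, a higher number a more soluble compound), for three compounds
Compound 1 `Cc1csc2nc(Cn3cnc4ccccc43)cc(=O)n12` (117000 nM)
Compound 2 `Cc1cccn2c(=O)cc(Cn3cnc4ccccc43)nc12` (529000 nM)
Compound 3 `COc1cccc(NS(=O)(=O)c2cc3c(cc2Cl)NC(=O)CO3)c1` (8600 nM)

Among these three, compound 1 stands second highest, with compound 2 higher and compound 3 lower, both gaps beyond the usual scatter. Compound 4 `O=c1cc(Cn2cnc3ccccc32)nc2sccn12` has not been measured yet. It differs from compound 1 in one place, with hydrogen in place of methyl on an aromatic carbon. Going by the values given here, no measured pair shows this change alone, so the expectation starts only from compound 1 (117000 nM). A small rise in this assay is expected, most likely within the scatter, and the estimated step stays modest (a 1.3-fold higher number from compound 1 to compound 4 (0.11 log units; within the scatter)). Compound 4 is expected at 150000 nM (estimated range 70000 nM to 320000 nM).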

Compound 4, solubility: 569000 nM
Compound 4: middle estimate off by 3.8-fold (0.58 log units), on the low side, and the stated range ends below it.
By their numbers in this assay, from the lowest: compound 3; then compound 1; then compounds 2 and 4 (each within the scatter of the next).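

In this assay, going by these compounds alone, hydrogen in place of methyl on the aromatic carbon next to the ring nitrogen gives a 4.9-fold higher number from compound 1 to compound 4 (0.69 log units; beyond the scatter), the first single-place step in this set. It shows that this one position on the five-membered aromatic ring can move the read-out beyond the scatter, even though the change removes only one heavy atom. Nothing measured here accounts for the size of this step. On these data alone, whether an ethyl group, a chlorine or an amine at this position would give a similar step stays open, as does whether the same methyl change would carry over to another core.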